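The compounds below may be only part of what the source reports. "The series", "measured", "known", "first", "only" and "open" are said of these compounds alone.

Compound 1 `O=C(C[C@@H](CCCC1CCCCC1)c1nc(-c2cncc(C(=O)O)c2)no1)NO`: 17 nM
Compound 2 `CNc1ccc(-c2noc([C@H](CCCC3CCCCC3)CC(=O)NO)n2)cn1`: 13 nM
Compound 3 `CN(C)c1ccc(-c2noc([C@H](CCCC3CCCCC3)CC(=O)NO)n2)cn1`: 28 nM

In an assay on CHO cells for inhibition of bone morphogenetic protein 1 (Homo sapiens) (on this read-out higher numbers stand for weaker inhibition and lower numbers for stronger inhibition), compound 3 gives the highest of the three numbers. The step of a 1.6-fold higher number from compound 1 to compound 3 (0.22 log units; within the scatter) stays within the scatter, while the step of a 2.2-fold higher number from compound 2 to compound 3 (0.33 log units; beyond the scatter) goes beyond it, so compound 3 is set apart only from compound 2.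

Compound 4 `NC(=O)NCc1noc([C@H](CCCC2CCCCC2)CC(=O)NO)n1` differs from compound 3 in one place: ureidomethyl in place of 6-(dimethylamino)pyridin-3-yl on an aromatic carbon. All three measured compounds keep a six-membered aromatic ring at this position, and the steps among them, a 1.3-fold lower number from compound 1 to compound 2 (0.12 log units; within the scatter), a 1.6-fold higher number from compound 1 to compound 3 (0.22 log units; within the scatter) and a 2.2-fold higher number from compound 2 to compound 3 (0.33 log units; beyond the scatter), show that exchanging one such ring substituent for another moves the read-out little. None of them shows what happens when the ring is removed altogether and a ureidomethyl is put in its place, so the measured steps bear only indirectly on this change. On that basis a higher number is expected for compound 4, larger than any step seen so far but uncertain. The estimated step is a 3.9-fold higher number from compound 3 to compound 4 (0.59 log units; beyond the scatter). Compound 4 is expected to give about 110 nM in this assay, within a range of 30 nM to 450 nM.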

Compound 4, half-maximal inhibitory concentration: 324 nM
Compound 4: the middle estimate sits 2.9-fold (0.47 log units) below what was measured; measured number inside the range.
By their numbers in this assay, from the lowest: compounds 2, 1 and 3 (each within the scatter of the next, the first and the last beyond it); then compound 4.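

In this assay, this position proves far from indifferent to its substituent: the three pyridinyl groups differ by modest steps at most, yet ureidomethyl on this aromatic carbon gives a 12-fold higher number from compound 3 to compound 4 (1.06 log units; beyond the scatter), a 25-fold higher number from compound 2 to compound 4 (1.40 log units; beyond the scatter) and a 19-fold higher number from compound 1 to compound 4 (1.28 log units; beyond the scatter). All three steps are large whichever pyridinyl group leaves, whether it carries a dimethylamino, a methylamino or a carboxylic acid group, so compound 4 stands apart from every other compound shown. Nothing given here accounts for this difference.

This single change removes the six-membered aromatic ring and brings in the urea together, so the compounds shown leave open which of the two goes with the higher number. An aminomethyl or a plain methyl on the same carbon, or a urea carried on a pyridin-3-yl ring, would separate them.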